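Chloro in Place of Nitro: Expected Binding Affinity

The source may hold more compounds than are shown below. What is called first, only, known or untested is meant among the compounds shown, and "the series" means these compounds.

Compound 1, `CCCN(CCC)c1cc(C)nc2c(-c3ncc(C(F)(F)F)cc3Cl)c(C)nn12`: 1.2 nM
Compound 2, `CCCN(CCC)c1cc(C)nc2c(-c3ncc([N+](=O)[O-])cc3C)c(C)nn12`: 9.1 nM

Both were tested in an assay on isolated protein for binding affinity to corticotropin-releasing factor receptor 1 (Homo sapiens); a lower number here means a stronger inhibitor, a higher number a weaker inhibitor. Compound 2 gives the higher of the two numbers; compound 1 gives a lower one, and that gap lies beyond the usual scatter. Compound 3, `CCCN(CCC)c1cc(C)nc2c(-c3ncc(Cl)cc3C)c(C)nn12`, has not been measured. It differs from compound 2 in one place: chloro in place of nitro on an aromatic carbon. Going by the values given here, no measured pair shows this exact change, so its size is uncertain. The step is expected to be a 1.8-fold lower number from compound 2 to compound 3 (0.26 log units; within the scatter), small and toward a lower number. Compound 3 is estimated at 5 nM, with a range from 1.5 nM to 15 nM.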

Compound 3, inhibition constant: 6.7 nM
Estimate against measurement, compound 3: 1.3-fold (0.13 log units) below, and the stated range covers the measured number.
By their numbers in this assay, from the lowest: compound 1; then compounds 3 and 2 (each within the scatter of the next).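

In this assay, chloro in place of nitro gives a 1.4-fold lower number from compound 2 to compound 3 (0.13 log units; within the scatter), so compound 2 and compound 3 cannot be told apart. At this position, then, a single chlorine atom matches the three-atom nitro group, even though the two hydrogen-bond acceptors of the nitro group are gone. Nothing measured here explains this match. As far as these compounds go, whether an amine or a carboxylic acid on this carbon would fit as well remains open. Compound 1 differs from compound 3 in two places, so its separate number cannot be assigned to either one.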